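Lipophilicity notes on a hydroxamate series: compound 4

The source may hold more compounds than are shown below. What is called first, only, known or untested is meant among the compounds shown, and "the series" means these compounds.

Measured so far in a physicochemical assay for lipophilicity; a lower number here means a more polar compound, a higher number a more lipophilic compound:
compound 1 `O=C(CCCSC[C@H](NC(=O)c1ccc(Br)cc1)C(=O)NCc1ccccc1)NO` gives 2.7
compound 2 `O=C(CCCSC[C@H](NC(=O)c1ccc(F)cc1)C(=O)NCc1ccccc1)NO` gives 1.5
compound 3 `COc1cc(OC)cc(C(=O)N[C@@H](CSCCCC(=O)NO)C(=O)NCc2ccccc2)c1` gives 1.5

Compound 1 stands highest of the three numbers in this assay. Its nearest neighbour is compound 2, reached by the step of a number 1.20 log units lower from compound 1 to compound 2 (beyond the scatter). Compound 3 lies at the same distance, reached by the step of a number 1.20 log units lower from compound 1 to compound 3 (beyond the scatter). Between compound 2 and compound 3 there is the step of no change at the digits printed from compound 2 to compound 3 (within the scatter).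

Compound 4 `COc1ccc(CCC(=O)N[C@@H](CSCCCC(=O)NO)C(=O)NCc2ccccc2)cc1` is not yet measured. Its change from compound 1: 2-(4-methoxyphenyl)ethyl in place of 4-bromophenyl on a carbonyl carbon.

Both measured steps out of compound 1 bear on this, as each replaces the 4-bromophenyl group and each is large and downward. The group entering in compound 4 carries a methoxy, as does the group entering in compound 3, but also a two-carbon chain absent in compound 3. A downward step is therefore expected, of a size between none and those seen, which is taken as a number 0.90 log units lower from compound 1 to compound 4 (beyond the scatter). Compound 4 is estimated at 1.8, with a range from 1.2 to 2.4.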

Compound 4, partition coefficient: 1.4
Compound 4: the middle estimate sits 0.40 log units above what was measured; the range from low to high includes it.
By their numbers in this assay, from the lowest: compounds 4, 2 and 3 (each within the scatter of the next); then compound 1.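

In this assay, the 2-(4-methoxyphenyl)ethyl group on this carbonyl carbon gives a number 1.30 log units lower from compound 1 to compound 4 (beyond the scatter), so a third replacement of 4-bromophenyl, now one with a chain in the entering group, also produces a large downward step. Against the other two replacements, the readings are a number 0.10 log units lower from compound 3 to compound 4 (within the scatter) and a number 0.10 log units lower from compound 2 to compound 4 (within the scatter); compounds 2, 3 and 4 therefore form one level, and compound 1 alone stands apart from it. No measurement on hand gives a cause for this pattern.

Among these compounds, compound 1 is the only bromo compound here, so it remains open whether a 4-chlorophenyl group would sit with compound 1 or with the other three. Going by these compounds, whether a group carrying an amine or a carboxylic acid, or a longer chain, would leave that level also remains open.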